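Enlarging a small ring: what happens to half-life?

The source may report more compounds than this note shows. Statements on the series, on what has been measured and on what is new or still open speak of the compounds shown alone.

In an in vitro ADME assay on microsomes (Mus musculus) for metabolic stability (on this read-out lower numbers stand for a shorter-lived compound and higher numbers for a longer-lived compound), compound 3 `Cc1c2c(n3c1CCN(C(=O)C1(N)CC1)C[C@@H](C)[C@H](C)Nc1cc-3ccc1C(N)=O)CC(C)(C)CC2=O` gives > 0.5 h, a limit and not a number. Compound 1 `Cc1c2c(n3c1CCN(C(=O)CN)C[C@@H](C)[C@H](C)Nc1cc-3ccc1C(N)=O)CC(C)(C)CC2=O` gives > 0.5 h, also a limit. Compound 2 `Cc1c2c(n3c1CCN(C(=O)[C@@H](N)C(C)C)C[C@@H](C)[C@H](C)Nc1cc-3ccc1C(N)=O)CC(C)(C)CC2=O` gives an actual number, 0.133 h. Compound 4 `Cc1c2c(n3c1CCN(C(=O)C1(N)CCCC1)C[C@@H](C)[C@H](C)Nc1cc-3ccc1C(N)=O)CC(C)(C)CC2=O` carries 1-aminocyclopentyl in place of 1-aminocyclopropyl on a carbonyl carbon. For the measured compounds named here, two measured steps bear on this change. Putting isopropyl on the chain brought an at least 3.7-fold lower number from compound 1 to compound 2 (0.57 log units; beyond the scatter), and 1-aminocyclopropyl in place of 1-amino-2-methylpropyl brought an at least 3.7-fold higher number from compound 2 to compound 3 (0.57 log units; beyond the scatter). Both lie beyond the scatter, and they suggest that a larger carbon group can cost half-life, though only compound 2 shows this. A lower number is therefore expected in this assay. The expected step is an at least 2.5-fold lower number from compound 3 to compound 4 (0.39 log units; beyond the scatter). For compound 4 the estimate is 0.2 h, with an expected range of 0.08 h to 0.5 h.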

Compound 4, half-life: 0.0833 h
The estimate for compound 4 lay 2.4-fold (0.38 log units) above the measured number; the measured number falls inside the stated range.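

In this assay, a ring on this carbonyl carbon does not by itself shorten half-life; its size matters, since 1-aminocyclopentyl in place of 1-aminocyclopropyl brought an at least 6.0-fold lower number from compound 3 to compound 4 (0.77 log units; beyond the scatter), and in place of aminomethyl it brought an at least 6.0-fold lower number from compound 1 to compound 4 (0.77 log units; beyond the scatter). Against 1-amino-2-methylpropyl, it brought a 1.6-fold lower number from compound 2 to compound 4 (0.20 log units; within the scatter), so a branched chain and this larger ring cannot be told apart here. The true size of the first two steps stays hidden, as each starts from a limit: the limit of > 0.5 h in this assay, at which 2 of the 4 values shown sit.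

Still open, on these data alone, is how half-life changes with 1-aminocyclobutyl, a ring size that would show whether the loss comes gradually or at once. As far as these compounds go, whether 1-aminocyclohexyl behaves like 1-aminocyclopentyl is also open.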